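This account rests on a few compounds, and the source may have more. Where it says the series, first, only, none or still open, it means among the compounds named here.

Working notes on the series.

Compound 1 `COc1ccccc1-n1cc(COc2c(/C=C\C(=O)O)ccc(OC)c2CC=C(C)C)nn1` is the reference point for this step, but in a functional assay on T47D cells (Homo sapiens) for cytotoxicity, read by MTT assay, with a stated time of 24 h (on this read-out lower numbers stand for stronger inhibition and higher numbers for weaker inhibition), compound 1 is recorded as "not determined" (no result reported), so there is no number to place it against. Within the data shown here, the only measured member of the series is compound 2 `COc1ccc(/C=C\C(=O)O)c(OCc2cn(-c3ccc(NC(=O)c4ccccc4)cc3)nn2)c1CC=C(C)C`, which in this assay gives 23300 nM, a weak effect on this read-out. Compound 3 `COc1cccc(-n2cc(COc3c(/C=C\C(=O)O)ccc(OC)c3CC=C(C)C)nn2)c1` has not been measured.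

The change from compound 1 to compound 3 is 3-methoxyphenyl in place of 2-methoxyphenyl on an aromatic nitrogen. Both compounds keep the same atoms and the same core; only the position of the methoxy group on the phenyl ring attached to the ring nitrogen is altered. Among the measured compounds shown here, with no pair of measured compounds that differ in one place, there is no step on which to size this change. For the measured compounds named here, the expectation is a step no larger than the usual scatter of this assay, in neither direction, since a move of a methoxy group within the same phenyl ring is a small alteration and the one measured value, from compound 2, sits in the weak range. Compound 3 is expected to give an estimated 25000 nM, with a range from 8000 nM to 80000 nM.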

Compound 3, half-maximal inhibitory concentration: 20400 nM
Estimate against measurement, compound 3: 1.2-fold (0.09 log units) above, within the range that was stated.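

In this assay compound 3 gives 20400 nM and compound 1 stands as "not determined" (no result reported) and no step can be read between these two compounds. What 3-methoxyphenyl in place of 2-methoxyphenyl does to the read-out stays open in the compounds shown. Nothing available here bears on a cause for the value of compound 3.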